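A few compounds are considered here, and "the series" means these few. Any claim that something is new, unique, unknown or untested is made for them only; others in the source may bear on it.

Compound 1 `CCn1c(-c2ccccc2)nc2c(NC3CCCCC3)ncnc21`: 10 nM
Compound 2 `CCn1c(-c2ccccc2)nc2c(N)ncnc21`: 31 nM

For the measured compounds named here, in an assay on CHO cells for displacement of a labelled ligand from adenosine receptor A1 (Homo sapiens), read by scintillation counting, with a stated time of 3 h (a higher number here means a weaker inhibitor, a lower number a stronger inhibitor), compound 2 stands at the highest of the two numbers measured; its only neighbour is compound 1, at 10 nM. Compound 3 `CCn1c(-c2ccccc2)nc2c(NC3CCCC3)ncnc21` differs from compound 2 in one place: cyclopentyl in place of hydrogen on a nitrogen on an aromatic ring. Going by the values given here, the single measured step that bears on this is a 3.1-fold higher number from compound 1 to compound 2 (0.49 log units; beyond the scatter), where removing the cyclohexyl ring raised the number. Adding a cyclopentyl ring in its place is therefore expected to reverse that step at about the same size, a 2.6-fold lower number from compound 2 to compound 3 (0.41 log units; beyond the scatter). Compound 3 is thus estimated at 12 nM, within a range from 5 nM to 30 nM.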

Compound 3, inhibition constant: 3.9 nM
Compound 3: the middle estimate sits 3.1-fold (0.49 log units) above what was measured; the measured number lies below the stated range.
By their numbers in this assay, from the lowest: compound 3; then compound 1; then compound 2.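

In this assay the cyclopentyl ring on this nitrogen gives a clear drop from the unsubstituted amino compound (a 7.9-fold lower number from compound 2 to compound 3 (0.90 log units; beyond the scatter)). Ring size also matters at this position, as exchanging cyclohexyl for cyclopentyl still changes the number (a 2.6-fold lower number from compound 1 to compound 3 (0.41 log units; beyond the scatter)). Nothing available explains why the five-membered ring gives the lower number. The compounds shown leave open how a cyclobutyl ring, a cycloheptyl ring or an open chain such as isopropyl would compare on the same nitrogen. They also leave open whether a hydroxyl on the cyclopentyl ring would be accepted.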